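Dropping the methoxy from the benzamide of compound 3

The compounds below may be only part of what the source reports. "The series", "measured", "known", "first", "only" and "open" are said of these compounds alone.

Compound 3 `COc1ccc(C(=O)Nc2nc(-c3ccc(OC)cc3)nc3cn(-c4ccccc4)nc23)cc1` holds the lowest number of the three measured compounds in an assay on CHO cells for displacement of a labelled ligand from adenosine receptor A3 (Homo sapiens), read by scintillation counting, with a stated time of 60 min (on this read-out lower numbers stand for stronger inhibition and higher numbers for weaker inhibition), where compound 3 gives 1.31 nM. Compound 1 `COc1ccc(-c2nc(N)c3nn(-c4ccccc4)cc3n2)cc1` gives 33 nM, and compound 2 `COc1ccc(-c2nc(NC(=O)c3ccncc3)c3nn(-c4ccccc4)cc3n2)cc1` gives 9.83 nM. The gaps are clear: there is a 25-fold lower number from compound 1 to compound 3 (1.40 log units; beyond the scatter) and a 7.5-fold lower number from compound 2 to compound 3 (0.88 log units; beyond the scatter), while there is a 3.4-fold lower number from compound 1 to compound 2 (0.53 log units; beyond the scatter).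

Compound 4 `COc1ccc(-c2nc(NC(=O)c3ccccc3)c3nn(-c4ccccc4)cc3n2)cc1` differs from compound 3 by hydrogen in place of methoxy on an aromatic carbon. Within the data shown here, no measured step removes a methoxy on its own; the nearest guide is the step from compound 2 to compound 3, in which a whole ring on the carbonyl carbon was exchanged and the number moved by a modest amount. The present change is a smaller cut at the same end of the molecule, so a step no larger than modest is expected, most likely toward a higher number, with a real chance that it stays within the scatter. Compound 4 is therefore expected to give 3 nM, between 1.2 nM and 8 nM, which amounts to an expected step of a 2.3-fold higher number from compound 3 to compound 4 (0.36 log units; beyond the scatter).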

Compound 4, inhibition constant: 6.42 nM
Compound 4: the middle estimate sits 2.1-fold (0.33 log units) below what was measured; measured number inside the range.
By their numbers in this assay, from the lowest: compound 3; then compounds 4 and 2 (each within the scatter of the next); then compound 1.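

In this assay, cutting the methoxy from the benzamide gives a 4.9-fold higher number from compound 3 to compound 4 (0.69 log units; beyond the scatter), so this single group on the aromatic carbon carries a real share of what the earlier whole-ring exchange showed only as a combined change. Exchanging pyridin-4-yl for phenyl on the carbonyl carbon gives a 1.5-fold lower number from compound 2 to compound 4 (0.19 log units; within the scatter), so that exchange alone does not register, and the gap between compound 2 and compound 3 appears only once the methoxy is present. The unsubstituted benzoyl on the nitrogen still gives a 5.1-fold lower number from compound 1 to compound 4 (0.71 log units; beyond the scatter), so part of the gain comes with the benzoyl itself and the methoxy adds to it.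

Nothing available gives a reason for these steps. The compounds shown leave open whether an ethoxy, a hydroxyl or a chlorine in place of this methoxy would match compound 3, and whether the 4-methoxyphenyl on the core matters in the same way.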